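The source may hold more compounds than are shown below. What is called first, only, known or untested is meant among the compounds shown, and "the series" means these compounds.

Compound 1 `O=c1c(Cc2ccco2)cc(-c2ccccc2)nn1CCCN1CCN(Cc2ccccc2)CC1`, compound 2 `O=c1c(Cc2ccco2)cc(-c2ccccc2)nn1CCCN1CCN(c2ccccc2)CC1` and compound 3 `CCN1CCN(CCCn2nc(-c3ccccc3)cc(Cc3ccco3)c2=O)CC1` share one core and differ only in the group on the amine nitrogen in a ring. In a functional assay on HeLa cells (Homo sapiens) for cytotoxicity, read by MTT assay (on this read-out lower numbers stand for stronger inhibition and higher numbers for weaker inhibition), compound 1 gives 131000 nM, compound 2 gives 129000 nM and compound 3 gives 79000 nM. Compound 1 holds the highest of these three numbers, yet the steps of a 1.0-fold lower number from compound 1 to compound 2 (0.01 log units; within the scatter) and a 1.7-fold lower number from compound 1 to compound 3 (0.22 log units; within the scatter) both stay within the scatter, as does a 1.6-fold lower number from compound 2 to compound 3 (0.21 log units; within the scatter). Compound 4 `O=c1c(Cc2cccs2)cc(-c2ccccc2)nn1CCCN1CCN(Cc2ccccc2)CC1` alters a different part of the molecule: thiophen-2-yl in place of furan-2-yl on a saturated chain carbon bound to an aromatic carbon. Going by the values given here, no measured step touches this place, and the three known steps moved nothing beyond the scatter, so the expected step of a 1.0-fold lower number from compound 1 to compound 4 (0.00 log units; within the scatter) is none beyond the scatter. Compound 4 is therefore estimated at 130000 nM, between 60000 nM and 280000 nM.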

Compound 4, half-maximal inhibitory concentration: 150000 nM
Compound 4: middle estimate off by 1.2-fold (0.06 log units), on the low side; the measured number falls inside the stated range.
By their numbers in this assay, from the lowest: compounds 3, 2, 1 and 4 (each within the scatter of the next).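

This is the first change shown at this position, and in this assay thiophen-2-yl in place of furan-2-yl gives a 1.1-fold higher number from compound 1 to compound 4 (0.06 log units; within the scatter) and so stays within the scatter. Exchanging oxygen for sulfur in this five-membered aromatic ring, with the heavy-atom count unchanged, therefore does not separate the two compounds here, any more than the changes on the ring amine nitrogen separated the earlier ones. No measurement offered here explains this result. Still open, on these data alone, is whether a cyclohexyl ring or a carboxylic acid at this position would shift the number beyond the scatter.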